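Cytotoxicity of a Nucleoside Series After an Amide Swap

This account rests on a few compounds, and the source may have more. Where it says the series, first, only, none or still open, it means among the compounds named here.

Measured so far:
compound 1 `Cc1cn([C@@H]2O[C@H](CO[Si](C)(C)C(C)(C)C)[C@@]3(OS(=O)(=O)C=C3NCC(N)=O)[C@H]2O[Si](C)(C)C(C)(C)C)c(=O)n(C)c1=O`, 14900 nM
compound 2 `Cc1cn([C@@H]2O[C@H](CO[Si](C)(C)C(C)(C)C)[C@@]3(OS(=O)(=O)C=C3NCC(=O)C(=O)N3CCC3)[C@H]2O[Si](C)(C)C(C)(C)C)c(=O)n(C)c1=O`, 17400 nM
compound 3 `CC(=O)NC1=CS(=O)(=O)O[C@@]12[C@@H](CO[Si](C)(C)C(C)(C)C)O[C@@H](n1cc(C)c(=O)n(C)c1=O)[C@@H]2O[Si](C)(C)C(C)(C)C`, 10700 nM

In a functional assay on MT4 cells (Homo sapiens) (on this read-out lower numbers stand for higher toxicity in this test and higher numbers for lower toxicity in this test), compound 2 gives the highest of the three numbers, yet its nearest neighbour compound 1 and its furthest neighbour compound 3 both lie within the scatter of it. Compound 4 `COC(=O)CC(=O)NC1=CS(=O)(=O)O[C@@]12[C@@H](CO[Si](C)(C)C(C)(C)C)O[C@@H](n1cc(C)c(=O)n(C)c1=O)[C@@H]2O[Si](C)(C)C(C)(C)C` differs from compound 2 in one place: ((methoxycarbonyl)methyl)carbonyl in place of (((azetidin-1-yl)carbonyl)carbonyl)methyl on an amine nitrogen. Among the compounds with values here, the steps that bear on this change are a 1.2-fold higher number from compound 1 to compound 2 (0.07 log units; within the scatter), a 1.6-fold lower number from compound 2 to compound 3 (0.21 log units; within the scatter) and a 1.4-fold lower number from compound 1 to compound 3 (0.14 log units; within the scatter), each within the scatter. Changes at this amine nitrogen have so far left this assay unmoved, so no step beyond the scatter is expected here. Compound 4 is therefore estimated at 13000 nM, in the range 6000 nM to 28000 nM, which means an expected step of a 1.3-fold lower number from compound 2 to compound 4 (0.13 log units; within the scatter).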

Compound 4, half-maximal cytotoxic concentration: 11900 nM
Beside the measured number, compound 4's estimate is 1.1-fold (0.04 log units) above it, within the range that was stated.
By their numbers in this assay, from the lowest: compounds 3, 4, 1 and 2 (each within the scatter of the next).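

Putting ((methoxycarbonyl)methyl)carbonyl in place of (((azetidin-1-yl)carbonyl)carbonyl)methyl on the amine nitrogen leaves this assay within the scatter (a 1.5-fold lower number from compound 2 to compound 4 (0.17 log units; within the scatter)). Methoxycarbonyl in place of hydrogen on the saturated chain carbon bound to a carbonyl carbon also stays within it (a 1.1-fold higher number from compound 3 to compound 4 (0.05 log units; within the scatter)), as does the swap from carbamoylmethyl (a 1.3-fold lower number from compound 1 to compound 4 (0.10 log units; within the scatter)), so the four groups on this nitrogen give numbers that cannot be told apart. Nothing available explains this result.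

Going by these compounds, whether a carboxylic acid or a primary amine at the end of this chain, or a longer chain, would give a step beyond the scatter stays open.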